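This account rests on a few compounds, and the source may have more. Where it says the series, first, only, none or still open, it means among the compounds named here.

In a functional assay on L1210 cells (Mus musculus) for cytotoxicity (a higher number here means a weaker inhibitor, a lower number a stronger inhibitor), compound 3 `O=C(/C=C/C(=O)N1C/C(=C\c2ccc([N+](=O)[O-])cc2)C(=O)/C(=C/c2ccc([N+](=O)[O-])cc2)C1)Nc1ccc(Cl)c(Cl)c1` gives 1700 nM and compound 1 `COc1ccc(NC(=O)/C=C/C(=O)N2C/C(=C\c3ccc([N+](=O)[O-])cc3)C(=O)/C(=C/c3ccc([N+](=O)[O-])cc3)C2)cc1` gives 2900 nM, two numbers within the scatter of each other. Compound 2 `Cc1cccc(C)c1NC(=O)/C=C/C(=O)N1C/C(=C\c2ccccc2)C(=O)/C(=C/c2ccccc2)C1` stands clearly higher at 22000 nM. Compound 4 `O=C(/C=C/C(=O)N1C/C(=C\c2ccc([N+](=O)[O-])cc2)C(=O)/C(=C/c2ccc([N+](=O)[O-])cc2)C1)Nc1ccc([N+](=O)[O-])cc1` has 4-nitrophenyl in place of 3,4-dichlorophenyl on an amide-type nitrogen of compound 3: 4-nitrophenyl in place of 3,4-dichlorophenyl on an amide-type nitrogen. Among the compounds with values here, the one measured exchange at that place, a 1.7-fold lower number from compound 1 to compound 3 (0.23 log units; within the scatter), stayed within the scatter, so no change beyond the scatter is expected in this assay, in either direction. One step is a thin guide, however, and it did not involve 4-nitrophenyl. The expected step is a 1.2-fold higher number from compound 3 to compound 4 (0.07 log units; within the scatter). The estimate for compound 4 is 2000 nM, with an expected range of 800 nM to 5000 nM.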

Compound 4, half-maximal inhibitory concentration: 1000 nM
Compound 4: the middle estimate sits 2.0-fold (0.30 log units) above what was measured; low and high end bracket the measured number.
By their numbers in this assay, from the lowest: compounds 4, 3 and 1 (each within the scatter of the next, the first and the last beyond it); then compound 2.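

In this assay, 4-nitrophenyl in place of 3,4-dichlorophenyl on the amide-type nitrogen stays within the scatter (a 1.7-fold lower number from compound 3 to compound 4 (0.23 log units; within the scatter)), so a second exchange at this position leaves the number unresolved from its neighbour. Nitro in place of methoxy on an aromatic carbon does go beyond the scatter, though only modestly (a 2.9-fold lower number from compound 1 to compound 4 (0.46 log units; beyond the scatter)), and this is the first step at this position to do so. Nothing available explains this step.

Going by these compounds, whether an amine or a carboxylic acid on that aromatic ring would keep the number in this range remains open.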